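The source may hold more compounds than are shown below. What is called first, only, known or untested is meant among the compounds shown, and "the series" means these compounds.

Compound 1 `O=C(/C(=C\c1ccc(OC(F)(F)F)cc1)S(=O)(=O)c1ccc(Br)cc1)c1ccc(Br)cc1`: 25000 nM
Compound 2 `O=C(/C(=C\c1ccc(O)c([N+](=O)[O-])c1)S(=O)(=O)c1ccc(I)cc1)c1ccc(I)cc1`: 25000 nM
Compound 3 `O=C(/C(=C\c1ccc(F)cc1)S(=O)(=O)c1ccc(Br)cc1)c1ccc(Br)cc1`: 4000 nM

Among these three compounds, all measured in a functional assay on DU-145 cells (Homo sapiens) for inhibition, read by trypan blue exclusion, with a stated time of 96 h (a higher number here means a weaker inhibitor of growth, a lower number a stronger inhibitor of growth), compound 3 stands lowest, with compound 1 and compound 2 both giving a higher number. Among the compounds with values here, the only measured step of a single change is a 6.3-fold lower number from compound 1 to compound 3 (0.80 log units; beyond the scatter). Compound 4 `O=C(/C(=C\c1c[nH]c2ccccc12)S(=O)(=O)c1ccc(Br)cc1)c1ccc(Br)cc1` differs from compound 3 by 1H-indol-3-yl in place of 4-fluorophenyl on a double-bonded chain carbon bound to a double-bonded chain carbon. Within the data shown here, the earlier step exchanged one substituent on the ring; this one exchanges the whole ring, and no measured pair shows such an exchange, so the earlier step bears on it only loosely. Compound 4 is therefore expected to show a step of a 2.0-fold higher number from compound 3 to compound 4 (0.30 log units; within the scatter), most likely a somewhat higher number, with wide uncertainty. The estimate for compound 4 is 8000 nM, between 2000 nM and 40000 nM.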

Compound 4, concentration for 50% growth inhibition: 25000 nM
Beside the measured number, compound 4's estimate is 3.1-fold (0.49 log units) below it; measured number inside the range.
By their numbers in this assay, from the lowest: compound 3; then compounds 1, 2 and 4 (each within the scatter of the next).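

In this assay, exchanging the whole ring on this double-bonded chain carbon moves the number as far as the earlier substituent change did: 1H-indol-3-yl in place of 4-fluorophenyl gives a 6.3-fold higher number from compound 3 to compound 4 (0.80 log units; beyond the scatter) and so a weaker inhibitor of growth. Compound 3 therefore keeps the lowest number against a second change at this place. Nothing measured here gives a reason for this step.

On these data alone, it remains open whether a pyridyl ring or a 1-methylindol-3-yl group would stay close to compound 3. As far as these compounds go, it is also open whether an amine on the phenyl ring would do so.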